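Adding a fluorine to the fused ring of compound 1

The source may hold more compounds than are shown below. What is called first, only, known or untested is meant among the compounds shown, and "the series" means these compounds.

Compound 1 `COc1cc2c(Oc3ccc(NC(=O)c4cc(-c5cccc(Cl)c5)nc5ccccc45)cc3F)ccnc2cc1OCCCN1CCC(C)CC1` is tested in a functional assay on MKN-45 cells (Homo sapiens) for cytotoxicity, read by MTT assay, with a stated time of 72 h (a higher number here means a weaker inhibitor, a lower number a stronger inhibitor), and gives 30 nM, the second highest of three numbers. Compound 2 `COc1cc2c(Oc3ccc(NC(=O)c4cc(-c5ccccc5)nc5ccccc45)cc3F)ccnc2cc1OCCCN1CCC(C)CC1` gives 19 nM, and compound 3 `COc1cc2c(Oc3ccc(NC(=O)c4cc(-c5ccc(C)cc5)nc5ccccc45)cc3F)ccnc2cc1OCCCN1CCC(C)CC1` gives 770 nM. Both known steps change the pendant phenyl ring: a 1.6-fold lower number from compound 1 to compound 2 (0.20 log units; within the scatter), while a 41-fold higher number from compound 2 to compound 3 (1.61 log units; beyond the scatter). Compound 4 `COc1cc2c(Oc3ccc(NC(=O)c4cc(-c5cccc(Cl)c5)nc5ccc(F)cc45)cc3F)ccnc2cc1OCCCN1CCC(C)CC1` instead alters the fused two-ring part of the shared core: fluoro in place of hydrogen on an aromatic carbon. Within the data shown here, no measured step touches this part, so there is no direct guide, and a small fluorine is expected to shift the number little. The step from compound 1 to compound 4 is therefore expected to be about no change at the digits printed from compound 1 to compound 4 (within the scatter), no change beyond the scatter. Compound 4 is estimated at 30 nM, between 12 nM and 75 nM.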

Compound 4, half-maximal inhibitory concentration: 10 nM
The estimate for compound 4 lay 3.0-fold (0.48 log units) above the measured number; measured number outside the range, below it.
By their numbers in this assay, from the lowest: compounds 4, 2 and 1 (each within the scatter of the next, the first and the last beyond it); then compound 3.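

Fluoro in place of hydrogen on this aromatic carbon, meta to a fused ring and para to a fused ring, gives a 3.0-fold lower number from compound 1 to compound 4 (0.48 log units; beyond the scatter) and so is a modest step, not a silent one. The fused ring of the shared core can therefore shift the number, which earlier steps on the pendant phenyl ring could not show. Nothing at hand accounts for this step.

On these data alone, whether fluoro acts the same way with the phenyl of compound 2 or the 4-methylphenyl of compound 3 remains open. So does the outcome of placing a nitrile or an amine on this carbon.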